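Phosphate aryl ester series on a fluorouracil nucleoside scaffold

The compounds below may be only part of what the source reports. "The series", "measured", "known", "first", "only" and "open" are said of these compounds alone.

Compound 1 `O=C(O[C@H]1C[C@H](n2cc(F)c(=O)[nH]c2=O)O[C@@H]1COP(=O)(O)Oc1cccnc1)c1ccccc1` is the reference. In a functional assay on U-118-MG cells (Homo sapiens) for cytotoxicity, read by MTT assay, with a stated time of 48 h (on this read-out lower numbers stand for stronger inhibition and higher numbers for weaker inhibition), compound 1 gives 920 nM. Compound 2 `O=C(O[C@H]1C[C@H](n2cc(F)c(=O)[nH]c2=O)O[C@@H]1COP(=O)(O)Oc1ccc2ncccc2c1)c1ccccc1` carries quinolin-6-yl in place of pyridin-3-yl on an oxygen and in this assay compound 2 gives 790 nM; the step of a 1.2-fold lower number from compound 1 to compound 2 (0.07 log units; within the scatter) is within the scatter and so shows no real change. Compound 3 `O=c1[nH]c(=O)n([C@H]2C[C@H](O)[C@@H](COP(=O)(O)Oc3cccnc3)O2)cc1F` differs from compound 1 in that hydrogen in place of benzoyl on an oxygen on a saturated carbon and in this assay compound 3 gives 27500 nM, the step of a 30-fold higher number from compound 1 to compound 3 (1.48 log units; beyond the scatter) being large.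

Compound 4 `O=c1[nH]c(=O)n([C@H]2C[C@H](O)[C@@H](COP(=O)(O)Oc3ccc4ncccc4c3)O2)cc1F` is not yet measured. Among the compounds with values here, it differs from compound 3 by quinolin-6-yl in place of pyridin-3-yl on an oxygen, which is the same change as the one from compound 1 to compound 2: both place lines read "on an oxygen whose other neighbours are: phosphorus", so the surroundings of the change are the same, while the two cores differ as given by hydrogen in place of benzoyl on an oxygen on a saturated carbon. This change has been made once among the measured pairs, and there it moved the number only within the scatter.

The expectation for compound 4 therefore rests on the step of a 1.2-fold lower number from compound 1 to compound 2 (0.07 log units; within the scatter) carried over onto the core of compound 3: the step of a 1.2-fold lower number from compound 3 to compound 4 (0.08 log units; within the scatter) is expected to be small and within the scatter. The estimate for compound 4 in this assay is 23000 nM, with a range from 9000 nM to 60000 nM. This rests on compound 3 giving 27500 nM and on the step of a 1.2-fold lower number from compound 1 to compound 2 (0.07 log units; within the scatter). Within the data shown here, only one measured instance of the change exists, so no firmer pattern is claimed.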

Compound 4, half-maximal inhibitory concentration: 7070 nM
Beside the measured number, compound 4's estimate is 3.3-fold (0.51 log units) above it, and the stated range ends above it.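

In this assay, quinolin-6-yl in place of pyridin-3-yl gives a 3.9-fold lower number from compound 3 to compound 4 (0.59 log units; beyond the scatter) on the core without benzoyl, so the change does not carry over at one size from the benzoyl-bearing core: the same change on two cores in this assay, a 1.2-fold lower number (0.07 log units; within the scatter) from compound 1 to compound 2 and a 3.9-fold lower number (0.59 log units; beyond the scatter) from compound 3 to compound 4, 3.3-fold (0.52 log units) apart, beyond the scatter of two such steps

Read along the other edge of the same set, hydrogen in place of benzoyl raises the number on both aryl esters, and with quinolin-6-yl the result is an 8.9-fold higher number from compound 2 to compound 4 (0.95 log units; beyond the scatter), the same direction as with pyridin-3-yl but a different size: the same change on two cores in this assay, a 30-fold higher number (1.48 log units; beyond the scatter) from compound 1 to compound 3 and an 8.9-fold higher number (0.95 log units; beyond the scatter) from compound 2 to compound 4, 3.3-fold (0.52 log units) apart, beyond the scatter of two such steps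

Both comparisons come from the same set of compounds and so form a single observation of dependence between the two places, which shows that a step measured on one core is a poor guide to its size on the other, but gives no general rule and no explanation for the difference.

Still open, from the compounds shown here alone, is whether this dependence extends to other groups on the phosphate oxygen, such as phenyl or naphthalen-2-yl, or to acetyl in place of benzoyl. Also open is whether the same behaviour appears in cells other than the one line shown here.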